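Swapping a phenyl substituent on a triazole-linked terpenoid

The source may report more compounds than this note shows. Statements on the series, on what has been measured and on what is new or still open speak of the compounds shown alone.

Measured so far:
Compound 1 `CC(C)=CCC/C(C)=C/CC/C(C)=C/CC[C@@H]1[C@@]2(C)CC/C(=N\OCc3cn(-c4cccc(O)c4)nn3)C(C)(C)[C@@H]2CC[C@@]1(C)O` gives 13500 nM in a functional assay on HeLa cells (Homo sapiens) for cytotoxicity, read by MTT assay, with a stated time of 48 h; a higher number here means a weaker inhibitor, a lower number a stronger inhibitor.
Compound 2 `CC(C)=CCC/C(C)=C/CC/C(C)=C/CC[C@@H]1[C@@]2(C)CC/C(=N\OCc3cn(-c4ccc(F)c(Cl)c4)nn3)C(C)(C)[C@@H]2CC[C@@]1(C)O` gives 20100 nM in this assay.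
Compound 3 `CC(C)=CCC/C(C)=C/CC/C(C)=C/CC[C@@H]1[C@@]2(C)C/C(=C\c3ccc(OCc4cn(-c5cccc(O)c5)nn4)cc3)C(=O)C(C)(C)[C@@H]2CC[C@@]1(C)O` gives 158000 nM in this assay.

Compounds 1 and 2 share one core; the change between them is 3-chloro-4-fluorophenyl in place of 3-hydroxyphenyl on an aromatic nitrogen, and it made the step of a 1.5-fold higher number from compound 1 to compound 2 (0.17 log units; within the scatter). Compound 3 carries a different core; how the core of compound 3 differs from the core of compound 1 is not broken down here. What is clear is that compound 3 gives the highest number of the three, beyond the scatter against both compound 1 and compound 2, so it is the weakest of the measured compounds in this assay.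

Compound 4 `CC(C)=CCC/C(C)=C/CC/C(C)=C/CC[C@@H]1[C@@]2(C)C/C(=C\c3ccc(OCc4cn(-c5ccc(F)c(Cl)c5)nn4)cc3)C(=O)C(C)(C)[C@@H]2CC[C@@]1(C)O` has not yet been measured. It stands to compound 3 as compound 2 stands to compound 1: the change is 3-chloro-4-fluorophenyl in place of 3-hydroxyphenyl on an aromatic nitrogen, the same change as before, made at the same place on the five-membered aromatic ring with 3 nitrogen. Among the measured compounds shown here, only one example of the change has been measured, so the expectation rests on a single step.

Because a 1.5-fold higher number from compound 1 to compound 2 (0.17 log units; within the scatter) lay within the scatter, the expected step for compound 4 is a 1.4-fold higher number from compound 3 to compound 4 (0.14 log units; within the scatter), also small. On that basis compound 4 is estimated at 220000 nM in this assay, with a range from 100000 nM to 500000 nM.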

Compound 4, half-maximal inhibitory concentration: 43000 nM
Estimate against measurement, compound 4: 5.1-fold (0.71 log units) above, and the stated range ends above it.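

On the core of compound 3, 3-chloro-4-fluorophenyl in place of 3-hydroxyphenyl gave a 3.7-fold lower number from compound 3 to compound 4 (0.57 log units; beyond the scatter) in this assay and so a stronger inhibitor, whereas on the core of compound 1 the same change stayed within the scatter. Set side by side, the same change does not give the same result on the two cores: the same change on two cores in this assay, a 1.5-fold higher number (0.17 log units; within the scatter) from compound 1 to compound 2 and a 3.7-fold lower number (0.57 log units; beyond the scatter) from compound 3 to compound 4, 5.5-fold (0.74 log units) apart, beyond the scatter of two such steps. Among the compounds shown here, this shows that the step measured on one core could not simply be carried over to the other, but with only one pair on each core it does not show which feature of the cores accounts for the gap, or whether another change at this place would depend on the core too.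

The compounds shown leave open how other groups on that aromatic nitrogen would behave on these two cores, such as a phenyl ring carrying an amine or a carboxylic acid, or a longer carbon chain in place of the ring. They also leave open whether this change on a third core would follow the pair of compound 1 and compound 2 or the pair of compound 3 and compound 4.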